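This account rests on a few compounds, and the source may have more. Where it says the series, first, only, none or still open, it means among the compounds named here.

Measured compounds:
compound 1, `O=C(O)CCC/C=C(/c1ccccc1)c1cccnc1` — 280 nM
compound 2, `C=C(C)C(CCC/C=C(\c1ccccc1)c1cccnc1)C(=O)O` — 28 nM

For the measured compounds named here, the two compounds measured so far share one core and differ in the chain that carries the acid. In an assay (Equus caballus) for inhibition of Thromboxane-A synthase (Homo sapiens), using microsomes (on this read-out lower numbers stand for stronger inhibition and higher numbers for weaker inhibition), compound 2 gives 28 nM, the lowest of the two numbers, and in this assay compound 1 gives 280 nM, a gap that lies beyond the usual scatter.

Compound 3, `O=C(O)CCC/C=C(\c1ccccc1)c1cccnc1`, has not yet been measured in this assay. It differs from compound 2 in one place: carboxy in place of 1-carboxy-2-methylprop-2-en-1-yl on a saturated chain carbon, three bonds along the chain from a double-bonded chain carbon. The branched acid group of compound 2 is thus cut back to a plain carboxy on the chain.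

Because compound 2 reaches 28 nM while the unbranched compound 1 stays at 280 nM, the expected step from compound 2 to compound 3 in this assay is a clear rise, estimated as a 7.1-fold higher number from compound 2 to compound 3 (0.85 log units; beyond the scatter). Compound 3 is therefore expected to give 200 nM in this assay, with a plausible range from 50 nM to 800 nM.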

Compound 3, half-maximal inhibitory concentration: 30 nM
For compound 3 the middle estimate is 6.7-fold (0.82 log units) above the measured one; measured number outside the range, below it.
By their numbers in this assay, from the lowest: compounds 2 and 3 (each within the scatter of the next); then compound 1.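

In this assay, cutting the 1-carboxy-2-methylprop-2-en-1-yl group back to carboxy on this saturated chain carbon gives a 1.1-fold higher number from compound 2 to compound 3 (0.03 log units; within the scatter), so the branched group of compound 2 is not needed for a value of this order. For the compounds shown here, the large step appears instead with the double bond alone, a 9.3-fold lower number from compound 1 to compound 3 (0.97 log units; beyond the scatter), and this step could not be read from the earlier compounds. Among these compounds, the change in the number can be tied to the double-bond configuration as drawn rather than to any other structural feature, because nothing else changes within this pair: the fact that compounds 1 and 3 differ only in the configuration as drawn

Going by these compounds, compound 2 and compound 3 carry the same double-bond configuration as drawn, so it remains open whether the 1-carboxy-2-methylprop-2-en-1-yl group would also make no clear difference on the other double-bond form. On these data alone, it is also open whether a longer chain between the double bond and the carboxy group, or an amide in place of the carboxylic acid, would keep the number at the level of compound 3.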